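The source may hold more compounds than are shown below. What is called first, only, known or untested is meant among the compounds shown, and "the series" means these compounds.

Measured compounds in a functional assay on the whole organism (strain albino Sprague-Dawley) with Rattus norvegicus as the target, in the maximal electroshock model; a higher number here means that more compound is needed for the effect, a lower number that less compound is needed:

- Compound 1 `CC(C)(C)[C@@H](N)C(=O)NCc1ccc(COc2cccc(F)c2)cc1` gives 30 mg/kg.
- Compound 2 `CC(C)[C@@H](N)C(=O)NCc1ccc(COc2cccc(F)c2)cc1` gives < 30 mg/kg, a limit of this assay rather than a number.
- Compound 3 `Cc1ccc(CNC(=O)[C@H](N)C(C)C)cc1` gives 50 mg/kg.

Compound 3 and compound 1 lie within the usual scatter of each other, so no order between them is claimed; compound 2 contributes only a limit. The step of a number no higher from compound 1 to compound 2 (the limit leaves the size open) is open in size, and the step of an at least 1.6-fold higher number from compound 2 to compound 3 (0.22 log units; that floor lies within the scatter) removes the 3-fluorophenoxy group at the benzylic carbon; neither touches the change now in question.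

Compound 4 `CC(C)[C@@H](N)C(=O)NCc1ccc(C(F)(F)F)cc1` differs from compound 3 by trifluoromethyl in place of methyl on an aromatic carbon. Among the compounds with values here, no measured step varies a substituent at that aromatic position, so nothing measured points to a shift beyond the scatter. The step of no change at the digits printed from compound 3 to compound 4 (within the scatter) is therefore expected to stay within the scatter. Compound 4 is estimated at 50 mg/kg, with a range from 20 mg/kg to 120 mg/kg.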

Compound 4, dose for half-maximal effect: 13 mg/kg
Estimate against measurement, compound 4: 3.8-fold (0.59 log units) above; measured number below the stated range.
By their numbers in this assay, from the lowest: compound 4; then compounds 1 and 3 (each within the scatter of the next).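

Trifluoromethyl in place of methyl on an aromatic carbon gives a 3.8-fold lower number from compound 3 to compound 4 (0.59 log units; beyond the scatter) in this assay and is the only step in the series printed as beyond the scatter. Within the data shown here, the position para to a group of 9 heavy atoms therefore responds to substitution, which no earlier step could show. No measured property shown bears on this step.

Going by these compounds, how a chlorine atom, a nitrile or a methoxy group at this aromatic carbon would compare remains open. Also open, on these data alone, is whether a single fluorine atom there would give a similar shift.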